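This account rests on a few compounds, and the source may have more. Where it says the series, first, only, none or still open, it means among the compounds named here.

Measured in a functional assay on the whole organism for agonist activity, with Mus musculus as the target; on this read-out higher numbers stand for an effect only at larger amounts of compound and lower numbers for an effect already at smaller amounts:
compound 1 `CC(=O)N(C)C(C)C#CCn1ccnc1`: 3 mg/kg
compound 2 `CC1CCC(=O)N1CC#CCn1ccnc1`: > 100 mg/kg (a limit, not a number)

Compound 2 has no number on this read-out, only the limit > 100 mg/kg. The gap to compound 1 therefore has no measured size. Within the data shown here, the two compounds show only that one gives a number and the other a limit in this assay.

The next compound is compound 3 `Cc1cncn1CC#CCN1C(=O)CCC1C`, which carries methyl in place of hydrogen on an aromatic carbon, methyl in place of hydrogen on an aromatic carbon. Among the measured compounds shown here, the series offers no measured step for this change, so nothing supports a gain, and no shift beyond the scatter is expected. Another limit is the likelier report. The expected step is a step that the limit leaves unreadable from compound 2 to compound 3. For compound 3 the estimated value in this assay is 120 mg/kg, with an expected range of 40 mg/kg to 300 mg/kg.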

Compound 3, dose for half-maximal effect: > 100 mg/kg
Compound 3: only a limit was reported (the forecaster's own chance of this, stated with the estimate: 65%); the middle value does not contradict the limit.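

In this assay compound 2 and compound 3 give only limits, not numbers, so no step can be read for methyl in place of hydrogen on an aromatic carbon: the limit of > 100 mg/kg in this assay, at which 2 of the 3 values shown sit.

On these data alone, whether this methyl shifts the dose for half-maximal effect at all stays open.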